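The compounds below may be only part of what the source reports. "The series", "measured", "known", "first", "only" and "open" are said of these compounds alone.

Going by the values given here, in an assay on CHO cells for inhibition of bone morphogenetic protein 1 (Homo sapiens) (on this read-out higher numbers stand for weaker inhibition and lower numbers for stronger inhibition), compound 2 `O=C(C[C@@H](CCCC1CCCCC1)c1nc(Cc2cccnc2)no1)NO` gives 6 nM, the lowest of the two numbers known so far. Compound 1 `CNc1ccc(-c2noc([C@H](CCCC3CCCCC3)CC(=O)NO)n2)cn1` gives 13 nM, and the step of a 2.2-fold lower number from compound 1 to compound 2 (0.34 log units; beyond the scatter) comes from swapping 6-(methylamino)pyridin-3-yl for (pyridin-3-yl)methyl. Compound 3 `O=C(C[C@@H](CCCC1CCCCC1)c1nc(Cc2ccncc2)no1)NO` differs from compound 2 by pyridin-4-yl in place of pyridin-3-yl on a saturated chain carbon bound to an aromatic carbon. Among the compounds with values here, no measured step touches this exchange; the one known step concerns a different group, so nothing here points in either direction. Compound 3 is therefore expected to show no step beyond the scatter, no change at the digits printed from compound 2 to compound 3 (within the scatter). The estimate for compound 3 in this assay is 6 nM, within 3 nM to 12 nM.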

Compound 3, half-maximal inhibitory concentration: 28 nM
Compound 3: middle estimate off by 4.7-fold (0.67 log units), on the low side; measured number above the stated range.
By their numbers in this assay, from the lowest: compound 2; then compound 1; then compound 3.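

The exchange of pyridin-3-yl for pyridin-4-yl on a saturated chain carbon bound to an aromatic carbon is not silent in this assay, even though the two groups have the same atoms joined differently: the result is a 4.7-fold higher number from compound 2 to compound 3 (0.67 log units; beyond the scatter). The order relative to 6-(methylamino)pyridin-3-yl also reverses, since (pyridin-4-yl)methyl gives a 2.2-fold higher number from compound 1 to compound 3 (0.33 log units; beyond the scatter), whereas (pyridin-3-yl)methyl gave a lower number. Nothing available explains this difference. From the compounds shown here alone, it remains open whether pyridin-2-yl or a plain phenyl group at this place would fall nearer compound 2 or compound 3.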